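The source may hold more compounds than are shown below. What is called first, only, known or untested is meant among the compounds shown, and "the series" means these compounds.

Measured compounds so far:

Compound 1 `COc1ccc(-c2nc(C(=O)/C=C\Nc3ccc(F)cc3)c3ccccn23)cc1`: in a functional assay on BT-474 cells (Homo sapiens) for cytotoxicity, read by MTT assay, with a stated time of 48 h (a lower number here means a stronger inhibitor, a higher number a weaker inhibitor), compound 1 gives > 30000 nM, which is a limit of the assay and not a number.
Compound 2 `Cc1cc2cc(N/C=C\C(=O)c3nc(-c4ccc(F)cc4)n4ccccc34)ccc2[nH]1`: in this assay compound 2 gives > 30000 nM, likewise only a limit.
Compound 3 `COc1ccc(N/C=C\C(=O)c2nc(-c3ccccc3)n3ccccc23)cc1`: in this assay compound 3 gives 12800 nM.

Compound 2 therefore stands at the weak end of what has been measured: its value is a limit, and it shares that position with compound 1, as noted in the limit of > 30000 nM in this assay, at which 2 of the 3 values shown sit. Within the data shown here, compound 3 is the only member of the series with a numerical value in this assay, and even that is weak. Among the measured compounds shown here, no pair of the measured compounds differs in a single place, so no measured step is available.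

The next compound is compound 4 `O=C(/C=C\Nc1ccc(Cl)cc1)c1nc(-c2ccc(F)cc2)n2ccccc12`, reached from compound 2 by 4-chlorophenyl in place of 2-methyl-1H-indol-5-yl on an amine nitrogen. Everything else in the two structures is the same.

Since nothing measured tracks this change, the expectation for the step of a number no higher from compound 2 to compound 4 (the limit leaves the size open) is none beyond the scatter, with the outcome most likely again a limit. For compound 4 in this assay the estimate is 30000 nM, within 8000 nM to 100000 nM.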

Compound 4, half-maximal inhibitory concentration: 7030 nM
Beside the measured number, compound 4's estimate is 4.3-fold (0.63 log units) above it; measured number outside the range, below it.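

In this assay, among these compounds, the group on the amine nitrogen is the first place where a single change can be read, and it moves the result: an at least 4.2-fold lower number from compound 2 to compound 4 (0.63 log units; beyond the scatter). Compound 2 gives > 30000 nM, which is a limit of the assay and not a number, while compound 4 gives 7030 nM, so this position responds to a change of group with the rest of the structure held the same. The upper size of the step stays open, and the limit is shared within the series: the limit of > 30000 nM in this assay, at which 2 of the 4 values shown sit.

One pair cannot separate the parts of this change, as 2-methyl-1H-indol-5-yl brings a five-membered aromatic ring and a hydrogen-bond donor that 4-chlorophenyl lacks, and 4-chlorophenyl brings the chlorine. As far as these compounds go, it remains open whether the chlorine itself matters, which an unsubstituted phenyl or a 4-bromophenyl on the amine nitrogen, with the rest of compound 4 unchanged, would address, and whether the same change holds on the other substitution patterns of the shared core.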